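Swapping the Aryl Group on a Pyrazoline Thiourea Series

The source may hold more compounds than are shown below. What is called first, only, known or untested is meant among the compounds shown, and "the series" means these compounds.

Measured so far:
compound 1 `S=C(Nc1ccccc1)N1N=C(c2ccccc2)CC1c1ccc2c(c1)OCCO2`, 1850 nM
compound 2 `S=C(Nc1ccccc1)N1N=C(c2ccc(Cl)cc2)CC1c1ccc2c(c1)OCCO2`, 195000 nM

Compound 2 stands at the highest of the two numbers in a functional assay on A-375 cells (Homo sapiens) for antiproliferative activity, read by MTT assay, with a stated time of 48 h; a higher number here means a weaker inhibitor of growth, a lower number a stronger inhibitor of growth; its nearest neighbour is compound 1, which gives 1850 nM. Going by the values given here, the only step on record, a 110-fold higher number from compound 1 to compound 2 (2.02 log units; beyond the scatter), shows that a change on this aryl ring can move the number a long way. Compound 3 `COc1cccc(C2=NN(C(=S)Nc3ccccc3)C(c3ccc4c(c3)OCCO4)C2)c1` differs from compound 2 as follows: 3-methoxyphenyl in place of 4-chlorophenyl on a carbon with a double bond to nitrogen. Among the compounds with values here, no measured step tells what 3-methoxyphenyl does here; what is known is that the unsubstituted phenyl of compound 1 sits far lower than the 4-chlorophenyl of compound 2. Compound 3 is therefore expected to fall between them, with the estimated step of a 13-fold lower number from compound 2 to compound 3 (1.11 log units; beyond the scatter), though with wide uncertainty. The estimated value for compound 3 is 15000 nM, with a range from 1500 nM to 150000 nM.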

Compound 3, concentration for 50% growth inhibition: 520 nM
Compound 3: middle estimate off by 29-fold (1.46 log units), on the high side, and the stated range ends above it.
By their numbers in this assay, from the lowest: compound 3; then compound 1; then compound 2.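

In this assay, the position on the carbon with a double bond to nitrogen proves able to carry a substituted phenyl without loss: the 3-methoxyphenyl gives a 3.6-fold lower number from compound 1 to compound 3 (0.55 log units; beyond the scatter), a modest step but beyond the scatter. The change from 4-chlorophenyl to 3-methoxyphenyl gives a 380-fold lower number from compound 2 to compound 3 (2.57 log units; beyond the scatter), so the large rise seen with 4-chlorophenyl does not extend to every substituted ring at this place. No measurement shown here explains why these two groups behave so differently.

Compound 2 and compound 3 differ both in the substituent and in where it sits on the phenyl ring, and the compounds shown do not separate those two changes. On these data alone, how an amine or a carboxylic acid on this ring would read also remains open.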